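Triazole aryl swap on a bicyclic lactam core

The source may report more compounds than this note shows. Statements on the series, on what has been measured and on what is new or still open speak of the compounds shown alone.

Measured so far in a functional assay on A549 cells (Homo sapiens) for inhibition, read by MTT assay, with a stated time of 24 h; on this read-out lower numbers stand for stronger inhibition and higher numbers for weaker inhibition:
compound 1 `CC1(C)[C@H]2CC[C@]1(C)N(Cc1cn(-c3cccc(F)c3)nn1)C(=O)C2`, 180 nM
compound 2 `CC1(C)[C@H]2CC[C@]1(C)N(Cc1cn(-c3ccccc3C#N)nn1)C(=O)C2`, 100 nM

Compound 2 gives the lowest of the two numbers in this assay, and its nearest neighbour is compound 1; the step of a 1.8-fold lower number from compound 1 to compound 2 (0.26 log units; within the scatter) lies within the scatter, so the two values cannot be told apart. Compound 3 `CC1(C)[C@H]2CC[C@]1(C)N(Cc1cn(-c3ccc(F)cc3)nn1)C(=O)C2` is not yet measured. It differs from compound 2 in one place: 4-fluorophenyl in place of 2-cyanophenyl on an aromatic nitrogen. Among the measured compounds shown here, the only measured step that bears on this change is the one from compound 1 to compound 2, where a fluorophenyl group was exchanged for the cyanophenyl group without any shift beyond the scatter. Compound 3 returns to a fluorophenyl group, and because a 1.8-fold lower number from compound 1 to compound 2 (0.26 log units; within the scatter) was small, compound 3 is expected to land near compound 1 and compound 2, with a step of a 1.6-fold higher number from compound 2 to compound 3 (0.20 log units; within the scatter). The estimate for compound 3 in this assay is 160 nM, in the range 60 nM to 420 nM.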

Compound 3, half-maximal inhibitory concentration: 230 nM
For compound 3 the middle estimate is 1.4-fold (0.16 log units) below the measured one; low and high end bracket the measured number.
By their numbers in this assay, from the lowest: compounds 2, 1 and 3 (each within the scatter of the next, the first and the last beyond it).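

In this assay, among the compounds shown here, 4-fluorophenyl in place of 2-cyanophenyl on the aromatic nitrogen gives a 2.3-fold higher number from compound 2 to compound 3 (0.36 log units; beyond the scatter), the first step at this position that lies beyond the scatter, though the step is modest. The two fluorophenyl groups, by contrast, cannot be told apart: 4-fluorophenyl in place of 3-fluorophenyl gives a 1.3-fold higher number from compound 1 to compound 3 (0.11 log units; within the scatter), so this read-out does not separate these two placements of the fluorine. Nothing measured here gives a reason for the step away from 2-cyanophenyl.

From the compounds shown here alone, what remains open is whether that step follows the nitrile itself or the place it occupies on the phenyl ring, as 2-cyanophenyl and 4-fluorophenyl differ in both. The compounds shown also leave open how an unsubstituted phenyl, a phenyl bearing an amine or one bearing a carboxylic acid would read at this position.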